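This account rests on a few compounds, and the source may have more. Where it says the series, first, only, none or still open, it means among the compounds named here.

Measured in a functional assay on CUTLL1 cells (Homo sapiens) for inhibition, read by resazurin assay, with a stated time of 48 h, in the absence of a further agent; a higher number here means that more compound is needed for the effect, a lower number that less compound is needed:
Compound 1 `Nc1ncc(-c2ccccn2)c(C2CC2)n1`: > 100000 nM, a limit.
Compound 2 `COc1ccc(-c2cnc(N)nc2C2CC2)cc1`: > 100000 nM, a limit.
Compound 3 `CC(C)c1nc(N)ncc1-c1ccncc1`: > 100000 nM, a limit.

Compound 3 gives no true number, only the limit > 100000 nM. It stands with the other two compounds at the limit of > 100000 nM in this assay, at which 3 of the 3 values shown sit. Compound 4 `Cc1nc(N)ncc1-c1ccncc1` differs from it in one place, with methyl in place of isopropyl on an aromatic carbon. Among the compounds with values here, no measured step shows what such a change does in this assay, so the only guide is that all three compounds remain at the limit. No change beyond the usual scatter is therefore expected, in either direction, and the estimated step is a number no higher from compound 3 to compound 4 (the limit leaves the size open). For compound 4 the expected value is 100000 nM, with an estimated range from 50000 nM to 200000 nM.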

Compound 4, half-maximal effective concentration: > 100000 nM
Compound 4 ended at the assay's limit; the forecaster's own chance of this, stated with the estimate: 85%; the middle value lies on the limit itself.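

Compound 3 and compound 4 both give only a limit, not a number, so no step between them can be read: the limit of > 100000 nM in this assay, at which 4 of the 4 values shown sit.

The compounds shown leave open how much of any of them this assay would need for the effect, and whether methyl in place of isopropyl changes that at all.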